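Replacing a cyanobenzyl arm with a methoxyphenoxy arm

This account rests on a few compounds, and the source may have more. Where it says the series, first, only, none or still open, it means among the compounds named here.

Compound 1 `COc1ccc(F)cc1CNCCCNc1ccnc2cc(Cc3ccc(C#N)cc3)ccc12` gives 6050 nM in an ADME assay on HepG2 cells (Homo sapiens) for cytotoxicity, read by luminescence, CellTiter-Glo and ATP content, with a stated time of 72 h (a lower number here means that less compound is needed, a higher number that more compound is needed for the effect), the highest of the three numbers; compound 2 `COc1ccc(-c2ccc3c(NCCCNCc4cccc(OC)c4O)ccnc3c2)cc1` gives 1600 nM and compound 3 `COc1cccc(CNCCCNc2ccnc3cc(-c4ccc(C(C)(C)C)cc4)ccc23)c1O` gives 690 nM. Among the measured compounds shown here, the only measured step, a 2.3-fold lower number from compound 2 to compound 3 (0.37 log units; beyond the scatter), concerns a different change and so does not bear directly on the move to compound 4 `COc1cccc(Oc2ccc3c(NCCCNCc4cc(F)ccc4OC)ccnc3c2)c1`, which carries 3-methoxyphenoxy in place of 4-cyanobenzyl on an aromatic carbon. For the measured compounds named here, with no step of this kind measured, the change is expected to leave compound 4 close to compound 1, with at most a modest move: the step of a 1.5-fold lower number from compound 1 to compound 4 (0.18 log units; within the scatter) is the estimate. Compound 4 is therefore expected to give 4000 nM in this assay, within a range from 1500 nM to 11000 nM.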

Compound 4, half-maximal effective concentration: 7100 nM
Estimate against measurement, compound 4: 1.8-fold (0.25 log units) below, and the stated range covers the measured number.
By their numbers in this assay, from the lowest: compound 3; then compound 2; then compounds 1 and 4 (each within the scatter of the next).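

In this assay, among the compounds shown here, the first measured step at this aromatic carbon, with the rest of compound 1 unchanged, is a 1.2-fold higher number from compound 1 to compound 4 (0.07 log units; within the scatter). Exchanging 4-cyanobenzyl for 3-methoxyphenoxy, arms with the same count of heavy atoms and one six-membered aromatic ring each, therefore gives no distinguishable change in this read-out. Nothing measured here offers an explanation for this result.

From the compounds shown here alone, whether a carboxylic acid or an amine on this aromatic carbon would shift the number beyond the scatter remains open. So does whether a longer chain in the arm would do so.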